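The source may hold more compounds than are shown below. What is called first, only, known or untested is meant among the compounds shown, and "the series" means these compounds.

Of the compounds shown here, three sharing one core have been measured in a functional assay on MCF7 cells (Homo sapiens) for inhibition, read by MTT assay, with a stated time of 72 h; on this read-out lower numbers stand for stronger inhibition of growth and higher numbers for weaker inhibition of growth. Compound 1 `O=S(=O)(NCCCCNCc1ccc(Br)cc1)c1cc(C(F)(F)F)cc(C(F)(F)F)c1` gives 1500 nM in this assay. Compound 2 `COc1ccc(CNCCCNS(=O)(=O)c2cc(C(F)(F)F)cc(C(F)(F)F)c2)cc1` gives 2500 nM in this assay. Compound 3 `O=S(=O)(NCCCNCc1cccc(Cl)c1)c1cc(C(F)(F)F)cc(C(F)(F)F)c1` gives 2600 nM in this assay, the highest of the three numbers, though all three sit close together: the steps of a 1.7-fold higher number from compound 1 to compound 2 (0.22 log units; within the scatter), a 1.7-fold higher number from compound 1 to compound 3 (0.24 log units; within the scatter) and a 1.0-fold higher number from compound 2 to compound 3 (0.02 log units; within the scatter) each stay within the scatter.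

Compound 4 `COc1cccc(CNCCCNS(=O)(=O)c2cc(C(F)(F)F)cc(C(F)(F)F)c2)c1` differs from compound 3 in one place: methoxy in place of chloro on an aromatic carbon. Among the compounds with values here, only the step from compound 2 to compound 3, which exchanged a 4-methoxyphenyl for a 3-chlorophenyl, is a near relative of this change, and it moved nothing beyond the scatter. The other two steps, each swapping one benzyl group for another, were likewise within the scatter. No step beyond the scatter is therefore expected in this assay for compound 4, and the expected step of no change at the digits printed from compound 3 to compound 4 (within the scatter) reflects that. Compound 4 is estimated at 2600 nM, with a range from 1300 nM to 5200 nM.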

Compound 4, concentration for 50% growth inhibition: 2400 nM
For compound 4 the middle estimate is 1.1-fold (0.03 log units) above the measured one; low and high end bracket the measured number.
By their numbers in this assay, from the lowest: compounds 1, 4, 2 and 3 (each within the scatter of the next).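

In this assay, a methoxy on this aromatic carbon, with its two heavy atoms and one hydrogen-bond acceptor, can stand in for a chloro with no visible effect: the change gives a 1.1-fold lower number from compound 3 to compound 4 (0.03 log units; within the scatter). The same holds for the first exchange that keeps the methoxy group and changes only the ring position, 3-methoxyphenyl in place of 4-methoxyphenyl, which gives a 1.0-fold lower number from compound 2 to compound 4 (0.02 log units; within the scatter), while the exchange of the whole (3-methoxybenzyl)amino end gives a 1.6-fold higher number from compound 1 to compound 4 (0.20 log units; within the scatter), so every step among these four compounds remains within the scatter. Nothing available explains this flat picture.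

Still open, going by these compounds, is whether any group on this aromatic carbon can move the number beyond the scatter, for example a carboxylic acid or an amine. The effect of a nitrile here is equally unknown.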